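The compounds below may be only part of what the source reports. "The series", "measured", "known", "first", "only" and "open" are said of these compounds alone.

For the measured compounds named here, compound 1 `COc1ccc2nc(C)cc(OCC(=O)Nc3ccccc3)c2c1` gives the higher of the two numbers so far recorded in a physicochemical assay for solubility, in phosphate buffer, measured as kinetic solubility, with a stated time of 1 h, at pH 7.4 (a higher number here means a more soluble compound, a lower number a less soluble compound), namely 63000 nM. Compound 2 `COc1ccc2nc(C)cc(OCC(=O)Nc3cc(OC)c(Cl)cc3OC)c2c1` gives 3000 nM in this assay, a gap that lies well beyond the scatter of repeated measurements. Compound 3 `COc1ccc2nc(C)cc(OCC(=O)Nc3ccncn3)c2c1` has not yet been measured; it differs from compound 1 in one place: pyrimidin-4-yl in place of phenyl on an amide-type nitrogen. Going by the values given here, no measured pair shows this exact change, so only a cautious expectation is possible: a small upward step, a 1.6-fold higher number from compound 1 to compound 3 (0.20 log units; within the scatter), near the edge of the scatter. Compound 3 is therefore estimated at 100000 nM in this assay, with a range from 40000 nM to 250000 nM.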

Compound 3, solubility: 27500 nM
Compound 3: middle estimate off by 3.6-fold (0.56 log units), on the high side; measured number outside the range, below it.
By their numbers in this assay, from the lowest: compound 2; then compound 3; then compound 1.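

For the compounds shown here, replacing phenyl with pyrimidin-4-yl on the amide-type nitrogen gives the first single-change comparison at this position: in this assay the swap produces a 2.3-fold lower number from compound 1 to compound 3 (0.36 log units; beyond the scatter) as a modest step. At this position, then, a six-membered aromatic ring with hetero atoms and hydrogen-bond acceptors gives a lower number than the all-carbon ring. Nothing at hand bears on the reason for this step.

Open, from the compounds shown here alone, is how other groups on this nitrogen would read, such as a pyridinyl ring. Going by these compounds, a phenyl ring carrying an amine or a carboxylic acid also remains untested here.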